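Ester to Acid: A Costly Change for Enzyme Inhibition

The source may report more compounds than this note shows. Statements on the series, on what has been measured and on what is new or still open speak of the compounds shown alone.

Compound 1 `COC(=O)c1cc(-c2cnc(C(=O)CCc3ccc(-c4ccccc4)cc3)o2)ccn1` is measured in an assay for inhibition of Fatty-acid amide hydrolase 1 (Rattus norvegicus) (on this read-out higher numbers stand for weaker inhibition and lower numbers for stronger inhibition), and gives 1.5 nM. Compound 3 `O=C(O)c1cc(-c2cnc(C(=O)CCc3ccc(-c4ccccc4)cc3)o2)ccn1` differs from it by hydrogen in place of methyl on an oxygen next to a carbonyl group; in this assay compound 3 gives 50 nM, and the step of a 33-fold higher number from compound 1 to compound 3 (1.52 log units; beyond the scatter) shows how much inhibition is lost. Compound 2 `COC(=O)c1cccc(-c2cnc(C(=O)CCc3ccc(OC4CCN(C(=O)OC(C)(C)C)CC4)cc3)o2)n1` is built on a different core; the difference between the two cores is not broken down here. In this assay compound 2 gives 32 nM, a number close to that of compound 3. Compound 4 `CC(C)(C)OC(=O)N1CCC(Oc2ccc(CCC(=O)c3ncc(-c4cccc(C(=O)O)n4)o3)cc2)CC1` is not yet measured and differs from compound 2 by hydrogen in place of methyl on an oxygen next to a carbonyl group, the same change at the same place as between compound 1 and compound 3. Compound 4 is expected to show a step of a 22-fold higher number from compound 2 to compound 4 (1.34 log units; beyond the scatter), resting on the earlier step of a 33-fold higher number from compound 1 to compound 3 (1.52 log units; beyond the scatter), which was large. The different core leaves room for a somewhat smaller or larger shift. Compound 4 is therefore estimated at 700 nM in this assay, with a likely range from 150 nM to 3500 nM.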

Compound 4, inhibition constant: 120 nM
Beside the measured number, compound 4's estimate is 5.8-fold (0.77 log units) above it; the whole stated range lies above it.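

Replacing methoxycarbonyl with carboxy weakens inhibition again in this assay, with a 3.8-fold higher number from compound 2 to compound 4 (0.57 log units; beyond the scatter), so the direction of the change carries over from the core of compound 1 to the core of compound 2. The size of the change does not carry over, and the two steps clearly differ: the same change on two cores in this assay, a 33-fold higher number (1.52 log units; beyond the scatter) from compound 1 to compound 3 and a 3.8-fold higher number (0.57 log units; beyond the scatter) from compound 2 to compound 4, 8.9-fold (0.95 log units) apart, beyond the scatter of two such steps. These two pairs give no reason for the gap, do not tell which part of the cores matters, and are too few to predict the size of the step on a third core.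

The compounds shown leave open how an ethyl ester or a primary amide in place of the methoxycarbonyl would compare on either core. They also leave open whether a core carrying a different group in place of the tert-butyl carbamate would give a step closer to the larger or the smaller one.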